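A few compounds are considered here, and "the series" means these few. Any claim that something is new, unique, unknown or untested is made for them only; others in the source may bear on it.

Measured so far: compound 2 `COCCNC(=O)c1c(O)c2ncc(Cc3ccc(F)cc3)cc2n(C)c1=O` gives 11.8 mL/min/kg; compound 1 `C[C@@H](CO)NC(=O)c1c(O)c2ncc(Cc3ccc(F)cc3)cc2n(C)c1=O` has no result, "not determined" (no result reported).

The account follows the step from compound 1 to compound 3 `Cn1c(=O)c(C(=O)NCCO)c(O)c2ncc(Cc3ccc(F)cc3)cc21`. In an ADME assay on the whole organism (plasma, strain CD) for pharmacokinetics, with Rattus norvegicus as the target (on this read-out lower numbers stand for slow clearance and higher numbers for fast clearance), compound 1 stands nowhere on the numbers: no single value was reported for it, so its position can only be read off its neighbour. Compound 2, which shares the core and differs from both in the amide side chain, gives 11.8 mL/min/kg in this assay. Compound 3 is reached from compound 1 by hydrogen in place of methyl on a saturated chain carbon bound to an amide-type nitrogen and a saturated chain carbon, a change of one carbon and no donor or acceptor. Within the data shown here, with no measured pair to set the size of such a step, no step beyond the usual scatter is expected between compound 1 and compound 3 in this assay. Compound 3 is therefore estimated at 12 mL/min/kg, within 5 mL/min/kg to 30 mL/min/kg, taking its cue from compound 2 at 11.8 mL/min/kg.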

Compound 3, clearance: 3.2 mL/min/kg
Estimate against measurement, compound 3: 3.8-fold (0.57 log units) above; measured number outside the range, below it.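

Among these compounds, compound 3 gives the first readable step on the amide side chain: in this assay hydrogen in place of methyl on an oxygen on a saturated carbon gives a 3.7-fold lower number from compound 2 to compound 3 (0.57 log units; beyond the scatter), a modest change but one beyond the scatter. The earlier compounds shown here could not show this, and it makes the side chain a place where the loss of a single methyl can move the clearance number, at least on this oxygen. Nothing at hand accounts for the step.

As far as these compounds go, the step from compound 1 to compound 3 cannot be read, as compound 1 has no number, so what the methyl on the saturated chain carbon does to clearance stays unknown. Also open, from the compounds shown here alone, is how an amine, a carboxylic acid or a longer chain on the amide would compare with compound 3.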